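A few compounds are considered here, and "the series" means these few. Any claim that something is new, unique, unknown or untested is made for them only; others in the source may bear on it.

Working notes on the anilino series built on the shared core, compared in a functional assay on MCF7 cells (Homo sapiens) for inhibition, read by sulforhodamine B assay; a lower number here means a stronger inhibitor, a higher number a weaker inhibitor. Compound 1 `O=C1C(Nc2cccc(Cl)c2)=CC(=O)c2c1nc1n2[C@H]2OC[C@@H](O)[C@H]2OC1` gives 2970 nM. Compound 2 `Cc1ccc(NC2=CC(=O)c3c(nc4n3[C@H]3OC[C@@H](O)[C@H]3OC4)C2=O)cc1` reaches only a limit of the assay, > 4000 nM. The step of an at least 1.3-fold higher number from compound 1 to compound 2 (0.12 log units; that floor lies within the scatter) is accordingly a floor, because it rests on (the limit of > 4000 nM in this assay, at which 1 of the 2 values shown sits). On the numbers shown, compound 2 stands at a limit rather than at a value. Compound 3 `O=C1C(Nc2ccccc2F)=CC(=O)c2c1nc1n2[C@H]2OC[C@@H](O)[C@H]2OC1` differs from compound 2 by 2-fluorophenyl in place of 4-methylphenyl on an amine nitrogen. Among the compounds with values here, no measured step carries this change, and the single step known is bounded by a limit, so no direction beyond the scatter can be read from it. The expected step that the limit leaves unreadable from compound 2 to compound 3 is close to none. Compound 3 is estimated at 4500 nM, within 1500 nM to 13000 nM.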

Compound 3, half-maximal inhibitory concentration: > 4000 nM
Compound 3: no number, only a limit (the forecaster's own chance of this, stated with the estimate: 50%); the middle value is on the limit's open side.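

In this assay compound 3 gives only a limit, > 4000 nM. Changing to 2-fluorophenyl on the amine nitrogen gives an at least 1.3-fold higher number from compound 1 to compound 3 (0.12 log units; that floor lies within the scatter), so this floor does not separate the two compounds beyond the scatter. The readings at this position now gather at one limit: the limit of > 4000 nM in this assay, at which 2 of the 3 values shown sit.

Going by these compounds, how far compound 2 and compound 3 lie past that limit stays open, and the step between them cannot be read. Also open, on these data alone, is whether a carboxylic acid or a longer chain in place of these aryl groups on the amine nitrogen would give a measurable number.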